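A few compounds are considered here, and "the series" means these few. Any claim that something is new, unique, unknown or untested is made for them only; others in the source may bear on it.

Of the compounds shown here, three built on a shared core have been tested in an ADME assay on HepG2 2.2.15 cells (Homo sapiens) for cytotoxicity; a lower number here means that less compound is tolerated, a higher number that more compound is tolerated. Compound 1 `Nc1c(-c2ccccc2F)c2cc(Cl)ccc2[nH]c1=O` gives 767000 nM. Compound 2 `Nc1c(-c2ccccc2Cl)c2cc(Cl)ccc2[nH]c1=O` gives 341000 nM, the lowest of the two plain numbers; the only difference between them is told by the step of a 2.2-fold lower number from compound 1 to compound 2 (0.35 log units; beyond the scatter). Compound 3 `O=c1[nH]c2ccc(Cl)cc2c(-c2ccccc2F)c1CCO` gives > 2990000 nM, which is a limit of the assay and not a number. That limit appears in the step of an at least 3.8-fold higher number from compound 1 to compound 3 (0.59 log units; beyond the scatter), where a 2-hydroxyethyl group replaced the amino group.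

Compound 4 `O=c1cc(-c2ccccc2Cl)c2cc(Cl)ccc2[nH]1` has not yet been measured. It differs from compound 2 in one place: hydrogen in place of amino on an aromatic carbon. Of the measured steps, an at least 3.8-fold higher number from compound 1 to compound 3 (0.59 log units; beyond the scatter) touches the same amino group, though what entered there was a 2-hydroxyethyl group rather than hydrogen, while a 2.2-fold lower number from compound 1 to compound 2 (0.35 log units; beyond the scatter) changes a different position and bears less directly. A modest rise is therefore expected, and compound 4 is estimated at 700000 nM, with a range from 250000 nM to 2000000 nM, meaning an expected step of a 2.1-fold higher number from compound 2 to compound 4 (0.31 log units; beyond the scatter) in this assay.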

Compound 4, half-maximal cytotoxic concentration: 6000000 nM
Estimate against measurement, compound 4: 8.6-fold (0.93 log units) below; the whole stated range lies below it.
By their numbers in this assay, from the lowest: compound 2; then compound 1; then compound 4.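

In this assay, taking away the amino group and leaving only hydrogen gives an 18-fold higher number from compound 2 to compound 4 (1.25 log units; beyond the scatter), so no new group has to enter at this position for the number to rise. This step is also clearly larger than the change on the other ring, a 2.2-fold lower number from compound 1 to compound 2 (0.35 log units; beyond the scatter), which makes the carbon two atoms from the ring nitrogen the more sensitive of the two places compared so far. Compound 3 is a limit and not a number, so the rise seen when 2-hydroxyethyl replaces amino has no exact size to set against the new step: the limit of > 2990000 nM in this assay, at which 1 of the 4 values shown sits.

On these data alone, whether hydrogen in place of amino gives a step of similar size with the fluoro group of compound 1 stays open. So does the effect of a methyl group, a methylamino group or a longer chain at this position.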